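This account rests on a few compounds, and the source may have more. Where it says the series, first, only, none or still open, it means among the compounds named here.

Working notes on the series. Going by the values given here, compound 1 `COC(=O)c1cccc(NC(=O)c2cc3cc([N+](=O)[O-])ccc3o2)c1` stands highest of the two numbers so far: in a physicochemical assay for solubility (on this read-out higher numbers stand for higher solubility and lower numbers for lower solubility), compound 1 gives 25 ug/mL, while compound 2 `CC(C)(C)OC(=O)NCc1ccccc1NC(=O)c1cnc2ccccc2c1` gives 15 ug/mL, a gap within the scatter, so neither can be ranked above the other. Compound 3 `NC(=O)c1cccc(NC(=O)c2cc3cc([N+](=O)[O-])ccc3o2)c1` is the next entry: compared with compound 1 it carries amino in place of methoxy on a carbonyl carbon. Among the compounds with values here, no step between measured compounds covers this change, so the expected step from compound 1 to compound 3 is a 1.2-fold higher number from compound 1 to compound 3 (0.08 log units; within the scatter), a small shift toward higher solubility that may not clear the scatter. For compound 3 the estimate is 30 ug/mL, with a range from 10 ug/mL to 90 ug/mL.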

Compound 3, solubility: 20 ug/mL
Compound 3: middle estimate off by 1.5-fold (0.18 log units), on the high side; the measured number falls inside the stated range.
By their numbers in this assay, from the lowest: compounds 2, 3 and 1 (each within the scatter of the next).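

In this assay, going by these compounds alone, carbamoyl in place of methoxycarbonyl on the core of compound 1 gives a 1.3-fold lower number from compound 1 to compound 3 (0.10 log units; within the scatter) and so cannot be told apart from no step at all. Within the data shown here, this is the first pair that differs in one place, and it shows amino in place of methoxy on a carbonyl carbon leaving the read-out inside the scatter. No evidence bears on the reason for this result.

As far as these compounds go, whether a carboxylic acid or a dimethylamino group on the same carbonyl carbon would clear the scatter stays open. So does whether this exchange reads alike on another core.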